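A few compounds are considered here, and "the series" means these few. Any claim that something is new, unique, unknown or untested is made for them only; others in the source may bear on it.

Compound 1 `COc1ccc(-c2nnc(SCCCN3CCN(c4nc5ccccc5o4)CC3)o2)cc1` gives 210000 nM
Compound 2 `COc1ccc(-c2nnc(SCCCN3CCN(c4nc5ccccc5s4)CC3)o2)cc1` gives 165000 nM

In a functional assay on HeLa cells (Homo sapiens) for inhibition, read by MTT assay, with a stated time of 72 h (on this read-out higher numbers stand for weaker inhibition and lower numbers for stronger inhibition), compound 2 gives 165000 nM and sits within the scatter of compound 1. Compound 3 `Cc1ccc(-c2nnc(SCCCN3CCN(c4nc5ccccc5s4)CC3)o2)cc1` has methyl in place of methoxy on an aromatic carbon. Among the compounds with values here, the only measured step (a 1.3-fold lower number from compound 1 to compound 2 (0.10 log units; within the scatter)) lies within the scatter and sits at a different place, an amine nitrogen in a ring, so no step beyond the scatter is expected for compound 3 in this assay. The estimated step is small (a 1.0-fold higher number from compound 2 to compound 3 (0.01 log units; within the scatter)). Compound 3 is estimated at 170000 nM (expected range 85000 nM to 340000 nM).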

Compound 3, half-maximal inhibitory concentration: 179000 nM
Beside the measured number, compound 3's estimate is 1.1-fold (0.02 log units) below it; measured number inside the range.
By their numbers in this assay, from the lowest: compounds 2, 3 and 1 (each within the scatter of the next).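

In this assay, within the data shown here, the swap of 4-methoxyphenyl for 4-methylphenyl gives a 1.1-fold higher number from compound 2 to compound 3 (0.04 log units; within the scatter) and so provides the first measured change at this place, on an aromatic carbon para to a large group. Removing the methoxy oxygen, and with it a hydrogen-bond acceptor, produces no step beyond the scatter here. Nothing measured here explains this result. Going by these compounds, whether an amine or a carboxylic acid on this aromatic carbon would give a step beyond the scatter remains open, and so does the outcome with a longer chain there.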